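Fluorophenoxy for dichlorophenylsulfanyl: expected growth inhibition

A few compounds are considered here, and "the series" means these few. Any claim that something is new, unique, unknown or untested is made for them only; others in the source may bear on it.

The series is followed in a functional assay on SK-MEL-28 cells (Homo sapiens) for inhibition, read by sulforhodamine B assay, with a stated time of 48 h; a lower number here means a stronger inhibitor of growth, a higher number a weaker inhibitor of growth. Compound 1 `COc1ccc(Sc2nc3cc(N)cc(N)c3nc2-c2ccccc2)cc1` is recorded only as a limit, < 100000 nM, with no number behind it. Among the measured compounds shown here, compound 2 `Nc1cc(N)c2nc(-c3ccccc3)c(Sc3ccc(Cl)c(Cl)c3)nc2c1` gives 57500 nM in this assay and is the only compound with a number here. For compound 1 the only other entry is the limit of < 100000 nM in this assay, at which 1 of the 2 values shown sits. The step that the limit leaves unreadable from compound 1 to compound 2 therefore cannot be read in size or direction.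

Compound 3 `Nc1cc(N)c2nc(-c3ccccc3)c(Oc3ccc(F)cc3)nc2c1` carries the change (4-fluorophenoxy in place of (3,4-dichlorophenyl)sulfanyl on an aromatic carbon). No measured step bears on this change, since the one step shown cannot be read, so nothing in the data suggests a direction or a size beyond the scatter in this assay. Compound 3 is therefore expected to sit near compound 2, estimated at 60000 nM in this assay, with a range of 20000 nM to 100000 nM. The expected step of a 1.0-fold higher number from compound 2 to compound 3 (0.02 log units; within the scatter) is thus estimated to lie within the usual scatter.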

Compound 3, concentration for total growth inhibition: 46800 nM
Beside the measured number, compound 3's estimate is 1.3-fold (0.11 log units) above it; the measured number falls inside the stated range.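

In this assay, 4-fluorophenoxy in place of (3,4-dichlorophenyl)sulfanyl on this aromatic carbon, next to the ring nitrogen and ortho to a phenyl group, gives a 1.2-fold lower number from compound 2 to compound 3 (0.09 log units; within the scatter). Among the compounds shown here, this is the first readable step at this position, and it shows that the sulfur link and the two chlorines can be exchanged together for an oxygen link and one fluorine with no shift beyond the scatter. The steps from compound 1 to compound 2 and to compound 3 cannot be read, since the entry for compound 1 is only a limit: the limit of < 100000 nM in this assay, at which 1 of the 3 values shown sits.

As far as these compounds go, because the link and the ring substituents change together here, the effect of each alone remains open. Also open, from the compounds shown here alone, is whether an amine, a carboxylic acid or a longer chain on this carbon would move the number in this assay beyond the scatter.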